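A few compounds are considered here, and "the series" means these few. Any claim that something is new, unique, unknown or untested is made for them only; others in the source may bear on it.

Measured in a functional assay on MC-38 cells (Mus musculus) for antiproliferative activity, read by colorimetric assay and MTT assay; a higher number here means a weaker inhibitor, a lower number a stronger inhibitor:
- compound 1 `O=[N+]([O-])c1ccc(S(=O)(=O)Nc2cccc3c(Cl)c[nH]c23)cc1`: 0.34 ug/mL
- compound 2 `Nc1ccc(S(=O)(=O)Nc2cccc3cc[nH]c23)cc1`: 6.1 ug/mL
- compound 3 `Nc1ccc(S(=O)(=O)Nc2cccc3c(Cl)c[nH]c23)cc1`: 0.23 ug/mL

Compound 3 stands level with compound 1 within the scatter, as the step of a 1.5-fold lower number from compound 1 to compound 3 (0.17 log units; within the scatter) shows, and well under compound 2, as the step of a 27-fold lower number from compound 2 to compound 3 (1.42 log units; beyond the scatter) shows. The next compound, compound 4 `Nc1ccc(S(=O)(=O)Nc2ccc(Br)c3c(Cl)c[nH]c23)cc1`, changes one place: bromo in place of hydrogen on an aromatic carbon. This is bromo in place of hydrogen on an aromatic carbon, para to a large group. Within the data shown here, no bromo compound has been measured yet. Among the measured compounds shown here, the nearest precedent is the step of a 27-fold lower number from compound 2 to compound 3 (1.42 log units; beyond the scatter), where chloro replaced hydrogen on an aromatic carbon, but that halogen entered at a different place, so its size cannot simply be carried over. The nitro-to-amino step, a 1.5-fold lower number from compound 1 to compound 3 (0.17 log units; within the scatter), does not bear on this position. Only a modest shift in this assay is therefore anticipated, towards a lower number if any, and it may well stay within the scatter. The expected change is a 1.3-fold lower number from compound 3 to compound 4 (0.11 log units; within the scatter). Compound 4 is estimated at 0.18 ug/mL, with an expected range from 0.05 ug/mL to 0.6 ug/mL.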

Compound 4, half-maximal inhibitory concentration: 0.14 ug/mL
The estimate for compound 4 lay 1.3-fold (0.11 log units) above the measured number, and the stated range covers the measured number.
By their numbers in this assay, from the lowest: compounds 4, 3 and 1 (each within the scatter of the next, the first and the last beyond it); then compound 2.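

In this assay, among these compounds, the carbon para to a large group carried only hydrogen in the earlier compounds, so compound 4 gives the first reading of a substituent there. Bromo in place of hydrogen on this aromatic carbon is tolerated, with a 1.6-fold lower number from compound 3 to compound 4 (0.22 log units; within the scatter): the atom adds bulk to the core without moving the number outside the scatter, unlike the chloro change elsewhere on the core, a 27-fold lower number from compound 2 to compound 3 (1.42 log units; beyond the scatter). Nothing available explains why this carbon accepts bromo so readily.

The compounds shown leave open whether a smaller fluoro, a methoxy group or a carboxylic acid on this carbon would also hold the number. They also leave open whether bromo here would behave the same way with hydrogen in place of the chloro.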